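The source may report more compounds than this note shows. Statements on the series, on what has been measured and on what is new or still open speak of the compounds shown alone.

For the measured compounds named here, in an ADME assay on microsomes from liver (Mus musculus, strain CD1) for metabolic stability, read by HPLC, using NADPH, with a stated time of 30 min, tested at 0.5 uM (a lower number here means slower removal, a higher number faster removal of the compound), compound 2 `CC[C@H]1CC[C@H](n2c(=O)[nH]c3ncc(NC(C)=O)cc3c2=O)CC1` gives 0.5 mL.min-1.g-1, the lowest of the three numbers so far. Compound 1 `CC(=O)Nc1cnc2[nH]c(=O)n([C@H]3CC[C@H](C(C)C)CC3)c(=O)c2c1` gives 1.4 mL.min-1.g-1 and compound 3 `CC[C@H]1CC[C@@H](n2c(=O)[nH]c3ncc(NC(C)=O)cc3c2=O)CC1` gives 2.7 mL.min-1.g-1. The two measured steps are a 2.8-fold lower number from compound 1 to compound 2 (0.45 log units; beyond the scatter) and a 5.4-fold higher number from compound 2 to compound 3 (0.73 log units; beyond the scatter), the second arising from the fact that compounds 2 and 3 differ only in the configuration as drawn.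

Compound 4 `CC[C@H]1CC[C@H](n2c(=O)[nH]c3ncc(N)cc3c2=O)CC1` is next, with hydrogen in place of acetyl on a nitrogen on an aromatic ring: acetamido to amino. Going by the values given here, all three measured compounds carry the acetamido group, so no measured step tests this change directly. Those steps only indicate the size of change seen so far, and both are modest. Compound 2 sits at the bottom of the set at 0.5 mL.min-1.g-1, and a step the size of a 2.8-fold lower number from compound 1 to compound 2 (0.45 log units; beyond the scatter) would leave more room upward than downward. The central expectation is therefore no shift beyond the scatter, with a slight upward lean, and the estimated step is a 1.6-fold higher number from compound 2 to compound 4 (0.20 log units; within the scatter). For compound 4 the expected value is 0.8 mL.min-1.g-1, with an estimated range of 0.3 mL.min-1.g-1 to 2.5 mL.min-1.g-1.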

Compound 4, intrinsic clearance in microsomes: 0.9 mL.min-1.g-1
Compound 4: middle estimate off by 1.1-fold (0.05 log units), on the low side; low and high end bracket the measured number.
By their numbers in this assay, from the lowest: compounds 2, 4, 1 and 3 (each within the scatter of the next, the first and the last beyond it).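

In this assay, the change from acetamido to amino on the nitrogen on the aromatic ring gives a 1.8-fold higher number from compound 2 to compound 4 (0.26 log units; within the scatter). The acetyl group can therefore go at this position without a shift beyond the scatter, which is unlike the change in configuration alone, with a 5.4-fold higher number from compound 2 to compound 3 (0.73 log units; beyond the scatter). Nothing available here bears on the reason for the size of the step from acetamido to amino.

Other groups on this nitrogen, such as a propionyl chain, a methanesulfonyl group or a urea, lie outside the compounds shown, so how much this position tolerates beyond acetyl and hydrogen remains open. Also open, from the compounds shown here alone, is whether acetamido to amino gives a similarly small step on the cores of compound 1 and compound 3.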